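The source may report more compounds than this note shows. Statements on the series, on what has been measured and on what is new or still open speak of the compounds shown alone.

Series notes, orexin receptor type 2 antagonism. Compound 1 `C[C@@H]1CC[C@@H](Oc2cc(C#N)ccn2)CN1C(=O)c1ccccc1CC(F)(F)F` carries a 2,2,2-trifluoroethyl group on the benzamide and a nitrile on the pyridine; in a functional assay on CHO-K1 cells for antagonist activity at Orexin receptor type 2 (Homo sapiens), read by FLIPR and calcium flux (on this read-out higher numbers stand for weaker inhibition and lower numbers for stronger inhibition), compound 1 gives 32 nM. Compound 2 `C#Cc1ccnc(O[C@@H]2CC[C@@H](C)N(C(=O)c3ccccc3-n3nccn3)C2)c1` pairs a triazolyl benzamide with a 4-ethynylpyridin-2-yl ether, and in this assay compound 2 gives 10 nM. Of the two numbers at hand compound 2 holds the lower one, and the gap to compound 1 lies beyond the scatter of repeats. The two compounds differ in more than one place, so no single step can be read from them.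

Compound 3 `Cc1cccc(O[C@@H]2CC[C@@H](C)N(C(=O)c3ccccc3-n3nccn3)C2)n1` keeps the core of compound 2 and changes only the aryl ether: 6-methylpyridin-2-yl in place of 4-ethynylpyridin-2-yl on an oxygen on a saturated carbon. Going by the values given here, no measured pair in this set isolates such a swap on the pyridine, so the size of the step has to be estimated without a reference. For compound 3 a moderate loss in this assay relative to compound 2 is expected, a 3.0-fold higher number from compound 2 to compound 3 (0.48 log units; beyond the scatter), since the ethynyl group that leaves has been part of the lowest number measured and nothing at hand shows a 6-methyl substituent matching it. Compound 3 is therefore estimated at 30 nM, with a plausible range from 8 nM to 120 nM.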

Compound 3, half-maximal inhibitory concentration: 33 nM
Compound 3: middle estimate off by 1.1-fold (0.04 log units), on the low side, within the range that was stated.
By their numbers in this assay, from the lowest: compound 2; then compounds 1 and 3 (each within the scatter of the next).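

Going by these compounds alone, with the core of compound 2 held fixed, the aryl ether on an oxygen on a saturated carbon is the only change, and in this assay placing 6-methylpyridin-2-yl in place of 4-ethynylpyridin-2-yl gives a 3.3-fold higher number from compound 2 to compound 3 (0.52 log units; beyond the scatter), the first step that can be read at a single place. This shows that the number in this assay responds to the aryl ether, but the two names differ both in the group and in its number on the pyridine, so the step cannot be assigned to the group alone or to its place alone. Nothing at hand accounts for the size of this step.

Open, on these data alone, is how 4-methylpyridin-2-yl and 6-ethynylpyridin-2-yl would read on the same core, since that pair of groups would separate the identity of the substituent from its place on the pyridine. Also open, as far as these compounds go, is how an unsubstituted pyridin-2-yl ether, or an amine or a methoxy group on the pyridine, would read against the ethynyl and methyl groups.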